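Oxolanylmethyl in Place of Trifluoromethylphenyl on the Ring Nitrogen

The source may hold more compounds than are shown below. What is called first, only, known or untested is meant among the compounds shown, and "the series" means these compounds.

Of the compounds shown here, two have been measured so far. Compound 1 `FC(F)(F)c1ccc(CN2CCN(Cc3cc(-c4ccc(OCc5ccccc5)cc4)on3)CC2)cc1` gives 1700 nM in a functional assay on Huh-7 cells (Homo sapiens) for antiproliferative activity, read by sulforhodamine B assay, with a stated time of 72 h; a higher number here means a weaker inhibitor, a lower number a stronger inhibitor. Compound 2 `N#Cc1cccc(COc2ccc(-c3cc(CN4CCN(c5ccc(C(F)(F)F)cc5)CC4)no3)cc2)c1` gives 2200 nM in this assay. Within the data shown here, the two numbers lie within the scatter of each other, so the data say only that both sit in the same region; no step between them can be read off, and no single-point step between measured compounds is available.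

The next compound keeps the nitrile-bearing benzyl ether and the shared core of compound 2 and changes only the group on the amine nitrogen in the ring: compound 3 `N#Cc1cccc(COc2ccc(-c3cc(CN4CCN(CC5CCCO5)CC4)no3)cc2)c1` differs from compound 2 by (oxolan-2-yl)methyl in place of 4-(trifluoromethyl)phenyl on an amine nitrogen in a ring.

Among the measured compounds shown here, with no measured step to anchor this change, the expectation rests on the two known values alone. The author expects compound 3 to give a somewhat higher number than compound 2, a step estimated as a 1.6-fold higher number from compound 2 to compound 3 (0.20 log units; within the scatter), just beyond the scatter. Compound 3 is therefore estimated at 3500 nM, with a range from 1200 nM to 10000 nM.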

Compound 3, half-maximal inhibitory concentration: 4200 nM
Compound 3: middle estimate off by 1.2-fold (0.08 log units), on the low side; measured number inside the range.
By their numbers in this assay, from the lowest: compounds 1, 2 and 3 (each within the scatter of the next, the first and the last beyond it).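

In this assay, among these compounds, the exchange on the amine nitrogen in a ring gives the first step that can be read between two compounds differing in one place (a 1.9-fold higher number from compound 2 to compound 3 (0.28 log units; within the scatter)). Since this step lies within the scatter, the data do not separate 4-(trifluoromethyl)phenyl, a six-membered aromatic ring of carbon only, from (oxolan-2-yl)methyl, a five-membered non-aromatic ring with 1 hetero atom, at this position, so neither group can be ranked above the other here. No measurement is at hand that would account for the size of this step.

The compounds shown leave open whether any other group on this nitrogen, such as a plain benzyl, an aminoethyl chain or a chain ending in a carboxylic acid, would move the number beyond the scatter. They also leave open whether the same exchange would give a similar step with a plain benzyl ether in place of the nitrile-bearing one, or with a methylene linking the 4-(trifluoromethyl)phenyl group to the ring nitrogen.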